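The compounds below may be only part of what the source reports. "The series", "measured", "known", "first", "only" and "open" are said of these compounds alone.

Compound 1 `NS(=O)(=O)c1ccc(Nc2nc(N/N=C/c3ccc(C(F)(F)F)cc3)nc(Nc3ccccc3)n2)cc1` and compound 2 `Cc1nn(-c2ccccc2)cc1/C=N/Nc1nc(Nc2ccccc2)nc(Nc2ccc(S(N)(=O)=O)cc2)n1` share one core and differ only in the group on the carbon with a double bond to nitrogen. In a functional assay on DU-145 cells (Homo sapiens) for inhibition, read by sulforhodamine B assay, with a stated time of 48 h (a lower number here means that less compound is tolerated, a higher number that more compound is tolerated), compound 1 gives 36700 nM. Compound 2 reaches only the limit of this assay, > 100000 nM, which is a boundary rather than a number. That step, an at least 2.7-fold higher number from compound 1 to compound 2 (0.43 log units; beyond the scatter), rests on (the limit of > 100000 nM in this assay, at which 1 of the 2 values shown sits). Compound 3 `NS(=O)(=O)c1ccc(Nc2nc(N/N=C/c3ccccn3)nc(Nc3ccccc3)n2)cc1` carries pyridin-2-yl in place of 3-methyl-1-phenyl-1H-pyrazol-4-yl on a carbon with a double bond to nitrogen. Within the data shown here, only that one step bears on this change, so the direction is uncertain. Compound 3 is expected to give about 70000 nM, within 25000 nM to 200000 nM, meaning an expected step of an at least 1.4-fold lower number from compound 2 to compound 3 (0.15 log units; that floor lies within the scatter).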

Compound 3, concentration lethal to 50% of the cells: > 100000 nM
Compound 3 ended at the assay's limit; the forecaster's own chance of this, stated with the estimate: 40%; at least 1.4-fold (0.15 log units) between middle value and limit.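

Pyridin-2-yl in place of 4-(trifluoromethyl)phenyl gives an at least 2.7-fold higher number from compound 1 to compound 3 (0.43 log units; beyond the scatter) in this assay, so the rise seen with compound 2 is not confined to one replacing group. The larger 3-methyl-1-phenyl-1H-pyrazol-4-yl and the smaller pyridin-2-yl on this carbon both move away from compound 1 in the same direction. The step between compound 2 and compound 3 cannot be read, and the two groups cannot be ranked, since both values are limits: the limit of > 100000 nM in this assay, at which 2 of the 3 values shown sit.

Of these three compounds, only compound 1 gives a value that is a true number. On these data alone, whether a plain phenyl, lacking the trifluoromethyl group, would stay near compound 1 or also reach the limit remains open.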